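Benzimidazole to aminopyridazine swap: expected microsomal clearance

The source may hold more compounds than are shown below. What is called first, only, known or untested is meant among the compounds shown, and "the series" means these compounds.

Compound 1 `Cc1cc(C)c(-c2nc3ccccc3[nH]2)cc1NC(=O)c1ccc(OCc2ccccn2)cc1` carries a 1H-benzimidazol-2-yl group on the shared core; in an ADME assay on microsomes from liver (Homo sapiens) for metabolic stability (a higher number here means faster removal of the compound, a lower number slower removal), compound 1 gives 30 mL.min-1.g-1, the lowest of the two numbers measured. Compound 2 `Cc1cc(C)c(-c2cccnc2)cc1NC(=O)c1ccc(OCc2ccccn2)cc1`, with pyridin-3-yl in the same place, gives 62 mL.min-1.g-1 in this assay, a step of a 2.1-fold higher number from compound 1 to compound 2 (0.32 log units; beyond the scatter). Compound 3 `Cc1cc(C)c(-c2ccc(N)nn2)cc1NC(=O)c1ccc(OCc2ccccn2)cc1` is not yet measured; it differs from compound 1 by 6-aminopyridazin-3-yl in place of 1H-benzimidazol-2-yl on an aromatic carbon. Within the data shown here, only the step from compound 1 to compound 2 bears on this, a modest rise for replacing the bicyclic group with a six-membered heteroaryl. A similar modest rise is therefore expected for compound 3 in this assay, estimated as a 1.5-fold higher number from compound 1 to compound 3 (0.18 log units; within the scatter). Compound 3 is expected near 45 mL.min-1.g-1, within 20 mL.min-1.g-1 to 95 mL.min-1.g-1.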

Compound 3, intrinsic clearance in microsomes: < 4 mL.min-1.g-1
Compound 3: a limit, no number; the forecaster's own chance of this, stated with the estimate: 5%; middle value at least 11-fold (1.05 log units) from the limit.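

In this assay compound 3 gives a limit of the assay, not a number: the limit of < 4 mL.min-1.g-1 in this assay, at which 1 of the 3 values shown sits. The swap to 6-aminopyridazin-3-yl runs against the earlier rise, with an at least 7.5-fold lower number from compound 1 to compound 3 (0.87 log units; beyond the scatter) and an at least 15-fold lower number from compound 2 to compound 3 (1.19 log units; beyond the scatter). This position therefore responds strongly to which six-membered heteroaryl enters, and such a group need not raise the number as pyridin-3-yl did.

How far the number falls remains unread behind the limit. Also open, going by these compounds, is whether the drop goes with the amino group or the pyridazine ring; a methoxy group in place of the amino group would separate the two.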